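Phenyl to Benzofuran: What Compound 4 Might Show

The source may report more compounds than this note shows. Statements on the series, on what has been measured and on what is new or still open speak of the compounds shown alone.

Compound 1, `COc1nc(N)nc2c1c(-c1ccccc1)cn2[C@@H]1O[C@H](CO)[C@@H](O)[C@H]1O`, gives in an ADME assay on BJ cells (Homo sapiens), read by MTT assay, with a stated time of 72 h (a higher number here means a weaker inhibitor, a lower number a stronger inhibitor), a limit of > 100000 nM. Compound 2, `Nc1nc(N)c2c(-c3ccccc3)cn([C@@H]3O[C@H](CO)[C@@H](O)[C@H]3O)c2n1`, gives in this assay a limit of > 100000 nM. Compound 3, `COc1ncnc2c1c(-c1ccccc1)cn2[C@@H]1O[C@H](CO)[C@@H](O)[C@H]1O`, gives in this assay a limit of > 100000 nM.

Compound 1 therefore stands only at a limit in this assay, and so do the two compounds measured beside it, as the limit of > 100000 nM in this assay, at which 3 of the 3 values shown sit, records. Neither step away from compound 1 can be read: the change from compound 1 to compound 2, amino in place of methoxy on an aromatic carbon, gives a step that the two limits leave unreadable from compound 1 to compound 2, and the change from compound 1 to compound 3, hydrogen in place of amino on an aromatic carbon, gives a step that the two limits leave unreadable from compound 1 to compound 3. The three compounds thus say nothing about which parts of the shared core matter in this assay beyond the fact that none of them reaches a readable number.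

Compound 4, `COc1nc(N)nc2c1c(-c1cc3ccccc3o1)cn2[C@@H]1O[C@H](CO)[C@@H](O)[C@H]1O`, differs from compound 1 at the aromatic carbon that carries the phenyl: 1-benzofuran-2-yl in place of phenyl on an aromatic carbon. Among the compounds with values here, no measured step touches this position, so the only guide is that every change tried so far left the compounds at the limit. Compound 4 is therefore expected to show a step of a number no higher from compound 1 to compound 4 (the limit leaves the size open), most likely again a limit rather than a number. The estimate for compound 4 in this assay is 100000 nM, within 30000 nM to 300000 nM.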

Compound 4, half-maximal inhibitory concentration: 25600 nM
Compound 4: the middle estimate sits 3.9-fold (0.59 log units) above what was measured, outside the stated range (below it).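

In this assay, within the data shown here, 1-benzofuran-2-yl in place of phenyl on an aromatic carbon of the five-membered aromatic ring with 1 nitrogen gives an at least 3.9-fold lower number from compound 1 to compound 4 (0.59 log units; beyond the scatter), so this place on the shared core can move the result off the limit, something the earlier compounds could not show. The steps from compound 1 to compound 2 and to compound 3, made at other places, cannot be read, which leaves this as the only readable step among the compounds shown. Compound 4 is also the only one of them with a number rather than a limit, and the other three stay at a single ceiling: the limit of > 100000 nM in this assay, at which 3 of the 4 values shown sit.

The compounds shown leave open which part of the entering group carries the step, the added five-membered aromatic ring with 1 hetero atom or the larger group as a whole, and a furan-2-yl or naphthalen-2-yl group at the same place would help to separate the two. They also leave open whether 1-benzofuran-2-yl would give a readable number with the amino group of compound 2 or the hydrogen of compound 3 in place of the groups that compound 4 carries.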